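From chloro to methoxy on compound 3

A few compounds are considered here, and "the series" means these few. Any claim that something is new, unique, unknown or untested is made for them only; others in the source may bear on it.

- compound 1 `COc1ccc(-c2nc(C)c(C(=O)CSc3nc(-c4ccc(OC)cc4)c(C#N)c(=O)[nH]3)s2)cc1` gives "not determined" (no result reported)
- compound 2 `COc1ccc(-c2nc(C)c(C(=O)CSc3nc(-c4ccc(OC)c(OC)c4)c(C#N)c(=O)[nH]3)s2)cc1` gives 23300 nM
- compound 3 `Cc1nc(-c2ccc(Cl)cc2)sc1C(=O)CSc1nc(-c2ccc(Cl)c(Cl)c2)c(C#N)c(=O)[nH]1` gives 46900 nM

All three entries come from an ADME assay on HEK293 cells (Homo sapiens) for cytotoxicity, read by MTT assay, with a stated time of 48 h (a lower number here means a stronger inhibitor, a higher number a weaker inhibitor), where compound 1 has no number to compare. Compound 3, at 46900 nM, lies within the usual scatter of compound 2, at 23300 nM, so the two cannot be ranked.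

Compound 4 `COc1ccc(-c2nc(C)c(C(=O)CSc3nc(-c4ccc(Cl)c(Cl)c4)c(C#N)c(=O)[nH]3)s2)cc1` has not yet been measured. It differs from compound 3 by one change, (methoxy in place of chloro on an aromatic carbon), which turns a 4-chlorophenyl into a 4-methoxyphenyl, para to a large group. Among the measured compounds shown here, no measured pair of compounds differing in one place is available to show the size of such a change. For the measured compounds named here, the only two numbers lie within the scatter of each other, so no step beyond the scatter is expected in this assay, in either direction. The estimated 1.4-fold lower number from compound 3 to compound 4 (0.15 log units; within the scatter) accordingly stays within the scatter. For compound 4 the expected value is 33000 nM, with an estimated range from 14000 nM to 75000 nM.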

Compound 4, half-maximal inhibitory concentration: 45600 nM
Compound 4: middle estimate off by 1.4-fold (0.14 log units), on the low side; the range from low to high includes it.
By their numbers in this assay, from the lowest: compounds 2, 4 and 3 (each within the scatter of the next).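

In this assay, among the compounds shown here, methoxy in place of chloro on an aromatic carbon, para to a large group, gives a 1.0-fold lower number from compound 3 to compound 4 (0.01 log units; within the scatter), which is the first reading of a change made in one place at this position, and it stays within the scatter. The second change, 3,4-dichlorophenyl in place of 3,4-dimethoxyphenyl on an aromatic carbon, gives a 2.0-fold higher number from compound 2 to compound 4 (0.29 log units; within the scatter), so neither of these two single changes separates its pair of compounds in this assay. Nothing measured here offers an explanation for these readings.

On these data alone, it remains open whether an amine or a carboxylic acid at this position would give a step beyond the scatter. As far as these compounds go, it also remains open whether a longer chain, such as butoxy, would do so.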